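The source may hold more compounds than are shown below. What is called first, only, known or untested is meant among the compounds shown, and "the series" means these compounds.

Measured so far in a functional assay on K562 cells (Homo sapiens) for antiproliferative activity, read by CCK-8 assay, with a stated time of 48 h; on this read-out lower numbers stand for stronger inhibition and higher numbers for weaker inhibition:
compound 1 `Cc1cc(Nc2cc(N3CCN(C)CC3)nc(Nc3ccc(F)cc3)n2)n[nH]1` — 357 nM
compound 2 `Cc1cc(Nc2cc(N3CCN(C)CC3)nc(Nc3cccc(F)c3)n2)n[nH]1` — 184 nM

Among the compounds with values here, compound 1 gives the highest number of the two, but its only neighbour, compound 2, sits within the scatter: a 1.9-fold lower number from compound 1 to compound 2 (0.29 log units; within the scatter). The two numbers therefore do not separate the two compounds.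

Compound 3 `Cc1cc(Nc2cc(N3CCN(C)CC3)nc(Nc3ccc(F)c(Cl)c3)n2)n[nH]1` is not yet measured. It differs from compound 1 in one place: chloro in place of hydrogen on an aromatic carbon. The fluoro group of compound 1 stays where it is; the chlorine is added on the same ring.

Within the data shown here, no measured step covers this change. Among the measured compounds shown here, the one step on record, from compound 1 to compound 2, moves the fluoro group rather than adding a chlorine, and it stays within the scatter, so it gives no direction for the added chloro. With nothing to lean on, the expectation for compound 3 is a number close to that of compound 1, with no step beyond the scatter: an estimated 1.2-fold lower number from compound 1 to compound 3 (0.08 log units; within the scatter).

The number expected for compound 3 in this assay is 300 nM, estimated to fall between 100 nM and 900 nM.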

Compound 3, half-maximal inhibitory concentration: 95.2 nM
Beside the measured number, compound 3's estimate is 3.2-fold (0.50 log units) above it; measured number outside the range, below it.
By their numbers in this assay, from the lowest: compounds 3, 2 and 1 (each within the scatter of the next, the first and the last beyond it).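

In this assay, within the data shown here, chloro in place of hydrogen on the 4-fluorophenyl group gives a 3.8-fold lower number from compound 1 to compound 3 (0.57 log units; beyond the scatter) and is the first step in this short series to lie beyond the scatter, so this ring does respond to a change in its substituents. The carbon ortho to a fluoro group and meta to a large group accepts a chlorine, and on this read-out the number falls rather than rises, something the earlier shift of the fluoro group could not show. The 3-chloro-4-fluorophenyl group is not separated from the 3-fluorophenyl group, however: the comparison shows a 1.9-fold lower number from compound 2 to compound 3 (0.29 log units; within the scatter) and so gives no reason to rank compound 3 apart from compound 2.

On these data alone, it remains open whether the step belongs to chlorine in particular, or whether methyl, methoxy, bromo or trifluoromethyl on the same carbon would give a similar number, and whether chloro would do the same on a ring without the fluoro group. No measurement at hand bears on why the added chloro lowers the number in this assay.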